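The source may hold more compounds than are shown below. What is called first, only, known or untested is meant among the compounds shown, and "the series" means these compounds.

Measured compounds:
compound 1 `O=C(/C=C/c1ccncc1-c1ccc2ccccc2c1)NC1CC1` — 6180 nM
compound 2 `NC(=O)/C=C/c1ccncc1Br` — "not determined" (no result reported)

For the measured compounds named here, in a functional assay on HCT-116 cells (Homo sapiens) for inhibition, read by MTT assay, with a stated time of 72 h (a higher number here means a weaker inhibitor of growth, a lower number a stronger inhibitor of growth), compound 1 gives 6180 nM and is the only compound of the series with a number; compound 2 has no result in this assay, so no comparison can be drawn from it. Compound 1 therefore stands alone as the reference point.

Compound 3 `CCOC(=O)/C=C/c1ccncc1-c1ccc2ccccc2c1` is not yet measured. It differs from compound 1 as follows: ethoxy in place of cyclopropylamino on a carbonyl carbon. The cyclopropylcarbamoyl end becomes an ethoxycarbonyl end on the same carbonyl carbon, the rest of the shared core is unchanged.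

Going by the values given here, no step between measured compounds is available to calibrate this change, so the direction is open. The step from compound 1 to compound 3 is expected to be modest, a 1.3-fold higher number from compound 1 to compound 3 (0.11 log units; within the scatter), with no clear direction beyond the usual scatter. Compound 3 is therefore estimated in this assay at 8000 nM, in the range 2000 nM to 32000 nM.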

Compound 3, concentration for 50% growth inhibition: 910 nM
Estimate against measurement, compound 3: 8.8-fold (0.94 log units) above; measured number outside the range, below it.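

In this assay ethoxy in place of cyclopropylamino on a carbonyl carbon brings a 6.8-fold lower number from compound 1 to compound 3 (0.83 log units; beyond the scatter) and so gives the first sign that this position responds to substitution, which compound 1 alone could not show. In this pair the stronger inhibitor of growth is compound 3, whose ethoxycarbonyl end has no hydrogen-bond donor and no ring, so neither the cyclopropyl ring nor the amide hydrogen is needed for activity at this level. Nothing at hand gives a cause for this step.

The change replaces the nitrogen, the hydrogen-bond donor and the three-membered ring in a single move, so the compounds shown cannot assign the step to any one of them. Ethylamino on the same carbonyl carbon would keep the donor without the ring, while methoxy or a carboxylic acid would test how far the oxygen-linked end can vary.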